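Replacing the acetyl group of a fast-cleared compound

A few compounds are considered here, and "the series" means these few. Any claim that something is new, unique, unknown or untested is made for them only; others in the source may bear on it.

Going by the values given here, in an ADME assay (liver) for metabolic stability, with Liver microsome (Rattus norvegicus) as the target, using microsomes and NADPH, with a stated time of 30 min (on this read-out higher numbers stand for fast clearance and lower numbers for slow clearance), compound 3 `CC#C[C@H]1CN(S(=O)(=O)c2ccc(N)nc2)CCN1c1ccc(C(C)=O)cc1` gives 249 mL.min-1.g-1, the highest number among the three compounds measured so far. Compound 1 `C#CCC(O)(c1ccc(N2CCN(S(=O)(=O)c3ccc(N)nc3)C[C@@H]2C#CC)cc1)C(F)(F)F` gives 59 mL.min-1.g-1, and the comparison shows a 4.2-fold higher number from compound 1 to compound 3 (0.63 log units; beyond the scatter). Compound 2 `CC#C[C@H]1CN(S(=O)(=O)c2ccc(N)nc2)CCN1c1ccc(S(C)(=N)=O)cc1` reads < 14 mL.min-1.g-1, which is a limit of the assay and not a number. The comparison with acetyl here shows an at least 17-fold higher number from compound 2 to compound 3 (1.25 log units; beyond the scatter).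

Compound 4 `CC#C[C@H]1CN(S(=O)(=O)c2ccc(N)nc2)CCN1c1ccc([C@](O)(CO)C(F)(F)F)cc1` has not yet been measured. Its difference from compound 3 is 1,2-dihydroxy-1-(trifluoromethyl)ethyl in place of acetyl on an aromatic carbon. In words, 1,2-dihydroxy-1-(trifluoromethyl)ethyl stands in place of acetyl on an aromatic carbon.

Among the compounds with values here, both measured compounds without acetyl lie well under compound 3, and no measured compound goes against this. The closest guide is compound 1 at 59 mL.min-1.g-1, as its group also carries a trifluoromethyl and a hydroxyl. Compound 4 differs from it in having a second hydroxyl, so a number near or somewhat under that of compound 1 seems reasonable. A clear drop is therefore expected in this assay, well beyond the scatter. The expected change is an 8.3-fold lower number from compound 3 to compound 4 (0.92 log units; beyond the scatter). For compound 4 the estimate is 30 mL.min-1.g-1, with an expected range from 14 mL.min-1.g-1 to 80 mL.min-1.g-1.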

Compound 4, intrinsic clearance in microsomes: < 14 mL.min-1.g-1
Compound 4 ended at the assay's limit (the forecaster's own chance of this, stated with the estimate: 25%); middle value at least 2.1-fold (0.33 log units) away from the limit.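

In this assay, putting 1,2-dihydroxy-1-(trifluoromethyl)ethyl in place of acetyl on this aromatic carbon gives an at least 17-fold lower number from compound 3 to compound 4 (1.25 log units; beyond the scatter), the first direct view of what this exchange does to the reading. The two groups that carry both trifluoromethyl and hydroxyl also differ from each other, with an at least 4.2-fold lower number from compound 1 to compound 4 (0.62 log units; beyond the scatter), so at this position the reading depends on more than those two features being present. Compound 2 and compound 4 both stand at a limit of the assay, not at a number, so the step between them cannot be read, and neither can how far under the limit either one lies: the limit of < 14 mL.min-1.g-1 in this assay, at which 2 of the 4 values shown sit.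

From the compounds shown here alone, what stays open is which part of the new group goes with the drop, and a plain hydroxymethyl or a lone trifluoromethyl on the same aromatic carbon would help to separate those parts. Going by these compounds, it is also open whether an amine or a carboxylic acid at this place would give a similarly low reading, and whether the mirror-image form of compound 4 would read the same.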